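The compounds below may be only part of what the source reports. "The series", "measured", "known", "first", "only" and "open" are said of these compounds alone.

Values in a functional assay on U-87MG ATCC cells for cytotoxicity against U-87 MG (Homo sapiens), read by MTT assay, with a stated time of 72 h (a higher number here means a weaker inhibitor, a lower number a stronger inhibitor), for the three measured compounds:
- compound 1 `COc1ncc(-c2ccc3nc(NC(=O)N4CCCC4)nn3c2)cc1NS(=O)(=O)c1ccc(F)cc1` gives 1690 nM
- compound 2 `COc1ncc(-c2ccc3nc(NC(=O)NCCN4CCCC4)nn3c2)cc1NS(=O)(=O)c1ccc(F)cc1` gives 1120 nM
- compound 3 `COc1ncc(-c2ccc3nc(NC(=O)NCCN(C)C)nn3c2)cc1NS(=O)(=O)c1ccc(F)cc1` gives 980 nM

Compound 3 stands level with the other two, and no order can be read among them. The step of a 1.7-fold lower number from compound 1 to compound 3 (0.24 log units; within the scatter) stays small, as does the step of a 1.1-fold lower number from compound 2 to compound 3 (0.06 log units; within the scatter) on the same chain. Compound 4 `COc1ncc(-c2ccc3nc(NC(=O)NCC(=O)N4CCOCC4)nn3c2)cc1NS(=O)(=O)c1ccc(F)cc1` is still unmeasured. It differs from compound 3 in one group, with (morpholin-4-yl)carbonyl in place of (dimethylamino)methyl on a saturated chain carbon bound to an amide-type nitrogen is the full count. The closest guides are a 1.1-fold lower number from compound 2 to compound 3 (0.06 log units; within the scatter) for a swap of one group on the chain and a 1.5-fold lower number from compound 1 to compound 2 (0.18 log units; within the scatter) for a change of the whole group on the carbonyl carbon. Among the compounds with values here, neither went beyond the scatter, and no measured compound carries the entering group. A step beyond the scatter is therefore not expected in this assay and no firm direction can be given. The estimated step is a 1.2-fold higher number from compound 3 to compound 4 (0.09 log units; within the scatter) and it should be read as no real change. For compound 4 the expected value is 1200 nM with an estimated range from 550 nM to 3000 nM in this test.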

Compound 4, half-maximal inhibitory concentration: 3260 nM
Compound 4: the middle estimate sits 2.7-fold (0.43 log units) below what was measured; the measured number lies above the stated range.
By their numbers in this assay, from the lowest: compounds 3, 2, 1 and 4 (each within the scatter of the next, the first and the last beyond it).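

In this assay, within the data shown here, the saturated chain carbon bound to an amide-type nitrogen is the first place where a change goes beyond the scatter: (morpholin-4-yl)carbonyl in place of (dimethylamino)methyl (a 3.3-fold higher number from compound 3 to compound 4 (0.52 log units; beyond the scatter)) and in place of (pyrrolidin-1-yl)methyl (a 2.9-fold higher number from compound 2 to compound 4 (0.46 log units; beyond the scatter)). Compounds 2 and 3 stood level, so exchanging one amine for another on this chain did not move the number, while this larger exchange did. The change is not visible against the shorter urea, since (((morpholin-4-yl)carbonyl)methyl)amino in place of pyrrolidin-1-yl on the carbonyl carbon stays within the scatter (a 1.9-fold higher number from compound 1 to compound 4 (0.29 log units; within the scatter)).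

A 2-(morpholin-4-yl)ethyl chain or a ((dimethylamino)carbonyl)methyl chain could show whether the ring or the carbonyl matters more. Nothing measured here explains why the number rises.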